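Urea to Thiourea on an Acetylated Sugar Chalcone

A few compounds are considered here, and "the series" means these few. Any claim that something is new, unique, unknown or untested is made for them only; others in the source may bear on it.

Measured compounds:
compound 1 `CC(=O)OC[C@H]1O[C@@H](CC(=O)/C=C/c2ccc(NC(=O)Nc3ccccc3)cc2)[C@H](OC(C)=O)[C@@H](OC(C)=O)[C@@H]1OC(C)=O` — 820000 nM
compound 2 `O=C(/C=C/c1cccc(NC(=S)Nc2ccccc2)c1)C[C@@H]1OC[C@@H](O)[C@H](O)[C@H]1O` — 289000 nM
compound 3 `Cc1ccc(S(=O)(=O)Nc2cccc(/C=C/C(=O)C[C@@H]3OC[C@@H](O)[C@H](O)[C@H]3O)c2)cc1` — 94700 nM

Of the compounds shown here, three have been tested in an ADME assay on Vero cells (Chlorocebus sabaeus) for cytotoxicity, read by resazurin assay, with a stated time of 2 days; a higher number here means that more compound is tolerated, a lower number that less compound is tolerated. Compound 1 stands highest of the three; its nearest neighbour is compound 2, and compound 3 lies furthest below it. Going by the values given here, the only step between compounds that differ in a single place is a 3.1-fold lower number from compound 2 to compound 3 (0.48 log units; beyond the scatter), which exchanges the thiourea-linked phenyl for a tosyl group on the aromatic nitrogen. Compound 1 and compound 2 differ in more than one place, so only their two values can be set side by side: compound 1 gives 820000 nM while compound 2 gives 289000 nM.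

Compound 4 `CC(=O)OC[C@H]1O[C@@H](CC(=O)/C=C/c2ccc(NC(=S)Nc3ccccc3)cc2)[C@H](OC(C)=O)[C@@H](OC(C)=O)[C@@H]1OC(C)=O` is the unmeasured partner of compound 1. The change is a group of 9 heavy atoms (7 carbon, 1 nitrogen, 1 sulfur; one six-membered aromatic ring of carbon only) in place of a group of 9 heavy atoms (7 carbon, 1 nitrogen, 1 oxygen; one six-membered aromatic ring of carbon only), on a nitrogen on an aromatic ring. Among the compounds with values here, no measured step isolates this exchange of oxygen for sulfur, and the step from compound 2 to compound 3 concerns a different group, so it gives little guidance on direction. Compound 4 is therefore expected to show at most a small step, a 1.5-fold lower number from compound 1 to compound 4 (0.17 log units; within the scatter), in this assay, not clearly beyond the scatter. Compound 4 is estimated at 550000 nM, with a range from 250000 nM to 1000000 nM.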

Compound 4, half-maximal cytotoxic concentration: 663000 nM
For compound 4 the middle estimate is 1.2-fold (0.08 log units) below the measured one; the measured number falls inside the stated range.
By their numbers in this assay, from the lowest: compound 3; then compound 2; then compounds 4 and 1 (each within the scatter of the next).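

In this assay, the exchange on a nitrogen on an aromatic ring, where the phenylcarbamoyl group gives way to its sulfur-bearing counterpart, is the first single change shown that replaces only oxygen by sulfur, and it gives a 1.2-fold lower number from compound 1 to compound 4 (0.09 log units; within the scatter), so that the two compounds cannot be told apart in this read-out. Going by these compounds alone, on the acetylated core shared by compound 1 and compound 4, this position therefore tolerates the urea and the thiourea alike, whereas the one earlier step, a 3.1-fold lower number from compound 2 to compound 3 (0.48 log units; beyond the scatter), exchanged a larger part of the group and lay beyond the scatter. No measurement offered here explains this result or bears on what lies behind it.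

What the compounds shown leave open is whether the same oxygen-for-sulfur exchange would also stay within the scatter on the core of compound 2, since this single pair speaks only for the acetylated core. Also open, from the compounds shown here alone, is how the number would respond if the phenyl ring of the urea were replaced by a longer alkyl chain, or if it carried an amine or a carboxylic acid.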